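The compounds below may be only part of what the source reports. "The series", "measured", "known", "first", "only" and "open" are said of these compounds alone.

Compound 2 `COc1cc(-c2nn(-c3cccc(NC(=O)Nc4cc(C(F)(F)F)cc(C(F)(F)F)c4)c3)cc2-c2ccncc2)ccc1Cl` stands in a functional assay on T47D cells (Homo sapiens) for inhibition, read by sulforhodamine B assay, with a stated time of 48 h (a lower number here means that less compound is tolerated, a higher number that more compound is tolerated), at a limit of the assay, > 50000 nM. Compound 3 `COc1cc(-c2nn(-c3cccc(NC(=O)Nc4cccc(C(F)(F)F)c4)c3)cc2-c2ccncc2)ccc1Cl` gives 50000 nM in this assay. Compound 1 `O=C(Nc1cccc(-n2cc(-c3ccncc3)c(-c3ccc(Cl)c(O)c3)n2)c1)Nc1cccc(C(F)(F)F)c1` sits at a limit as well, > 32500 nM. Compound 4 `O=C(Nc1cccc(-n2cc(-c3ccncc3)c(-c3ccc(Cl)c(O)c3)n2)c1)Nc1cc(C(F)(F)F)cc(C(F)(F)F)c1` differs from compound 2 by hydrogen in place of methyl on an oxygen on an aromatic ring. The same change in reverse appears as a step that the limit leaves unreadable from compound 1 to compound 3, which the limit of > 32500 nM in this assay, at which 1 of the 3 values shown sits, leaves unreadable; the other measured step, a number no higher from compound 2 to compound 3 (the limit leaves the size open), likewise rests on the limit of > 50000 nM in this assay, at which 1 of the 3 values shown sits, and carries no readable size. Going by the values given here, no measured step therefore sets a direction for the change from methoxy to hydroxy. For compound 4 the expected step of a number no higher from compound 2 to compound 4 (the limit leaves the size open) is none beyond the scatter. Compound 4 is estimated at 50000 nM, between 20000 nM and 120000 nM, and is expected most likely to return only a limit again.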

Compound 4, concentration lethal to 50% of the cells: > 50000 nM
Compound 4: only a limit was reported; the forecaster's own chance of this, stated with the estimate: 80%; the middle value lies on the limit itself.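

In this assay, going by these compounds alone, compound 4 returns only a limit, > 50000 nM, so no step from compound 1 or compound 2 to compound 4 can be read. The compounds shown leave open what methoxy to hydroxy does in this assay.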